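A few compounds are considered here, and "the series" means these few. Any claim that something is new, unique, unknown or untested is made for them only; others in the source may bear on it.

Working notes on the cinnamamide-thienopyrimidine series.

Three compounds have been run in a functional assay on HepG2 cells (Homo sapiens) for antiproliferative activity, read by MTT assay, with a stated time of 48 h; on this read-out higher numbers stand for weaker inhibition and lower numbers for stronger inhibition. Compound 1 `O=C(/C=C/c1ccccc1)Nc1cc2c(Nc3ccc(Cl)c(Cl)c3)ncnc2s1` gives 30100 nM. Compound 2 `O=C(/C=C/c1ccccc1)Nc1cc2ncnc(Nc3cc(Cl)cc(Cl)c3)c2s1` gives 10700 nM, the lowest of the three numbers. Compound 3 `O=C(/C=C/c1ccccc1)Nc1cc2c(Nc3cc(Cl)cc(Cl)c3)ncnc2s1` gives 21800 nM. Compound 2 stands apart from both, with compound 3 the nearer and compound 1 the further.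

Compound 1 and compound 3 share a core and differ only in one place, (3,4-dichlorophenyl in place of 3,5-dichlorophenyl on a nitrogen on an aromatic ring). This change gave a 1.4-fold higher number from compound 3 to compound 1 (0.14 log units; within the scatter), so within the scatter the two are indistinguishable.

The cores of compound 2 and compound 3 differ; that difference is not broken down here.

Compound 4 `O=C(/C=C/c1ccccc1)Nc1cc2ncnc(Nc3ccc(Cl)c(Cl)c3)c2s1` has not been measured. It relates to compound 2 as compound 1 relates to compound 3: 3,4-dichlorophenyl in place of 3,5-dichlorophenyl on a nitrogen on an aromatic ring. The place lines of the two changes agree word for word, so this is the same change made on the other core. Within the data shown here, on that basis the step from compound 2 to compound 4 in this assay is expected to be small, about a 1.4-fold higher number from compound 2 to compound 4 (0.15 log units; within the scatter), resting on the single earlier step seen between compound 3 and compound 1 and on the value of compound 2. Compound 4 is therefore estimated at 15000 nM, with a plausible range from 7000 nM to 32000 nM.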

Compound 4, half-maximal inhibitory concentration: 13400 nM
For compound 4 the middle estimate is 1.1-fold (0.05 log units) above the measured one; low and high end bracket the measured number.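

In this assay, 3,4-dichlorophenyl in place of 3,5-dichlorophenyl on the nitrogen gives a 1.3-fold higher number from compound 2 to compound 4 (0.10 log units; within the scatter), and this step agrees with the earlier one on the other core: the same change on two cores in this assay, a 1.4-fold higher number (0.14 log units; within the scatter) from compound 3 to compound 1 and a 1.3-fold higher number (0.10 log units; within the scatter) from compound 2 to compound 4, 1.1-fold (0.04 log units) apart, within the scatter of two such steps

On both cores of this series, then, moving between these two dichlorophenyl groups leaves the number within the scatter, and the small step seen on one core carried over to the other. This does not show that a large step would carry over in the same way, since the agreement rests on one change, two cores and two steps that are both small, and it says nothing about any further core or any other cell line.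

All the compounds shown carry a dichlorophenyl group on the nitrogen and an unchanged cinnamamide, so the step sizes remain open for groups such as fluoro, methoxy or a carboxylic acid in place of the chlorines. Also open, as far as these compounds go, is whether an amine or a longer chain at that same nitrogen would keep the two cores in step.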